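A few compounds are considered here, and "the series" means these few. Any claim that something is new, unique, unknown or untested is made for them only; others in the source may bear on it.

Measured in a physicochemical assay for lipophilicity, in phosphate buffer, measured as octanol-water partition, at pH 11.5; on this read-out higher numbers stand for higher lipophilicity and lower numbers for lower lipophilicity:
- Compound 1 `CCCCCCCCNC(=N)NC(=N)Nc1ccccc1`: 4.43
- Compound 2 `CCCCCCCCNC(=N)NC(=N)Nc1ccc(C)cc1`: 4.93
- Compound 3 `CCCCCCCCNC(=N)NC(=N)Nc1ccc(Cl)cc1`: 5.13

Compound 3 stands at 5.13, at the top of this small set, a place it shares with compound 2. The measured steps to it are a number 0.20 log units higher from compound 2 to compound 3 (within the scatter) and a number 0.70 log units higher from compound 1 to compound 3 (beyond the scatter).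

Compound 4 `CCCCCCCCNC(=N)NC(=N)Nc1ccc(OC)cc1` carries methoxy in place of chloro on an aromatic carbon. Among the measured compounds shown here, no measured compound holds methoxy, so the guides are the modest rises seen on replacing hydrogen, a number 0.50 log units higher from compound 1 to compound 2 (beyond the scatter) and a number 0.70 log units higher from compound 1 to compound 3 (beyond the scatter). Methoxy differs from chloro and methyl in holding a hydrogen-bond acceptor, so a modest fall towards the value of compound 1 seems likely, though its size remains uncertain.

The expected change is a number 0.53 log units lower from compound 3 to compound 4 (beyond the scatter).

Compound 4 is estimated at 4.6, with an expected range of 4.2 to 5.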

Compound 4, partition coefficient: 4.41
Estimate against measurement, compound 4: 0.19 log units above; the measured number falls inside the stated range.
By their numbers in this assay, from the lowest: compounds 4 and 1 (each within the scatter of the next); then compounds 2 and 3 (each within the scatter of the next).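

Replacing hydrogen with methoxy at this position gives a number 0.02 log units lower from compound 1 to compound 4 (within the scatter) in this assay and so, unlike methyl and chloro, brings no measurable rise. Methoxy instead gives a number 0.72 log units lower from compound 3 to compound 4 (beyond the scatter) when it replaces chloro and a number 0.52 log units lower from compound 2 to compound 4 (beyond the scatter) when it replaces methyl. Which group sits on this aromatic carbon therefore matters, not merely that hydrogen is replaced.

Going by these compounds, whether an amine, a carboxylic acid or a longer ether chain here would stay level with compound 1 remains open. Nothing available explains why methoxy parts from methyl and chloro.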